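Solubility notes: from 4-fluorophenyl to 4-cyanophenyl

The source may report more compounds than this note shows. Statements on the series, on what has been measured and on what is new or still open speak of the compounds shown alone.

Of the compounds shown here, two have numbers so far in a physicochemical assay for solubility, read by spectrophotometry, in phosphate buffer, with a stated time of 18 h, at pH 7.4; on this read-out lower numbers stand for lower solubility and higher numbers for higher solubility. Compound 1 (`Cc1ccc(-c2nc3c(c(C)nn3-c3ccccc3)c(-c3ccccc3O)c2C#N)cc1`) gives 26000 nM. Compound 2 (`Cc1nn(-c2ccccc2)c2nc(-c3ccc(F)cc3)c(C#N)c(-c3ccccc3O)c12`) gives 6000 nM, the lower of the two numbers.

Compound 3 (`Cc1nn(-c2ccccc2)c2nc(-c3ccc(C#N)cc3)c(C#N)c(-c3ccccc3O)c12`) is next, with cyano in place of fluoro on an aromatic carbon, para to a large group, so that 4-fluorophenyl becomes 4-cyanophenyl: cyano in place of fluoro on an aromatic carbon.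

Among the measured compounds shown here, only one measured step bears on this change: a 4.3-fold lower number from compound 1 to compound 2 (0.64 log units; beyond the scatter), modest but beyond the scatter. That step exchanges methyl for fluoro, so it shows that the number in this assay can move with this substituent, but it says nothing directly about cyano. For the measured compounds named here, no measured compound carries cyano there. Going by the values given here, a modest step of similar or smaller size is therefore expected, leaning downward as in the one precedent, though the direction is weakly supported and an upward move is not excluded. The estimated change is a 1.7-fold lower number from compound 2 to compound 3 (0.23 log units; within the scatter). For compound 3 the expected value is 3500 nM, with an estimated range of 1000 nM to 12000 nM.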

Compound 3, solubility: 1700 nM
For compound 3 the middle estimate is 2.1-fold (0.31 log units) above the measured one; low and high end bracket the measured number.
By their numbers in this assay, from the lowest: compound 3; then compound 2; then compound 1.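

In this assay, the 4-fluorophenyl to 4-cyanophenyl change gives a 3.5-fold lower number from compound 2 to compound 3 (0.55 log units; beyond the scatter), so this position has now produced a second step beyond the scatter, and it runs in the same direction as a 4.3-fold lower number from compound 1 to compound 2 (0.64 log units; beyond the scatter). Across the three groups the numbers fall in the order methyl, fluoro, cyano, with no compound shown going against that order, and the two modest steps add up to a large one, a 15-fold lower number from compound 1 to compound 3 (1.18 log units; beyond the scatter), so the substituent at this single place spans a wide range of the read-out while the rest of the structure stays fixed. Nothing available explains why the number falls across these three groups, and the entry of the nitrile cannot be tied to the drop on the data at hand.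

Whether an amine, a carboxylic acid or a methoxy group at this place would extend the fall or reverse it remains open, since the three compounds shown cover only methyl, fluoro and cyano here. Also open, going by these compounds, is whether the same order would hold on a core changed elsewhere, since all three compounds share one core.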